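A few compounds are considered here, and "the series" means these few. Any claim that something is new, unique, unknown or untested is made for them only; others in the source may bear on it.

Measured so far:
Compound 1, `CC(C)(C)[C@H](C(=O)Nc1ncc(Br)s1)c1ccc(Cl)cc1`: 95%
Compound 2, `CCC[C@H](C(=O)Nc1nccs1)c1ccc(Cl)cc1`: 108%

In a functional assay on CHO cells for agonist activity at Free fatty acid receptor 2 (Homo sapiens), read by cAMP accumulation (on this read-out higher numbers stand for larger maximal responses and lower numbers for smaller maximal responses), compound 1 gives 95% and compound 2 gives 108%. Compound 2 stands highest of the two numbers, and its gap to compound 1 lies beyond the usual scatter of repeated measurements. Compound 3, `COCC[C@H](C(=O)Nc1nccs1)c1ccc(Cl)cc1`, has not yet been measured. It differs from compound 2 in one place: methoxy in place of methyl on a saturated chain carbon, three bonds along the chain from an aromatic carbon and a carbonyl carbon. Within the data shown here, no pair of measured compounds isolates this change, so there is no measured step to lean on. A large response is expected for compound 3 because compound 2 reaches 108%, a level already near a full response, and a small change on the saturated chain carbon is not expected to move it beyond the scatter in either direction. Compound 3 is therefore expected to give about 100% in this assay, within a range from 80% to 120%. This estimate means an expected step of a number 8 percentage points lower from compound 2 to compound 3 (within the scatter), staying within the scatter.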

Compound 3, largest response reached (reported as efficacy), in percent of the reference or control that the assay uses: 53%
Beside the measured number, compound 3's estimate is 47 percentage points above it; the measured number lies below the stated range.
By their numbers in this assay, from the lowest: compound 3; then compound 1; then compound 2.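

In this assay, putting methoxy in place of methyl on a saturated chain carbon, three bonds along the chain from an aromatic carbon and a carbonyl carbon, gives a number 55 percentage points lower from compound 2 to compound 3 (beyond the scatter) and so shows that the maximal response depends strongly on what sits at the end of this chain. Compound 1 and compound 2 differ in more than one place, so they could not reveal this on their own. Nothing available here explains why the response falls.

From the compounds shown here alone, it remains open whether the loss goes with the oxygen itself or with the longer chain, a question that a butyl group in place of the propyl chain could help settle. An amine or a hydroxyl group at the chain end would show whether other groups there give a similar response.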